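From benzoyl to pivaloyl on the piperidine nitrogen

A few compounds are considered here, and "the series" means these few. Any claim that something is new, unique, unknown or untested is made for them only; others in the source may bear on it.

Compound 1 `Fc1ccc(C(SCCNC2CCN(Cc3ccccc3)CC2)c2ccc(F)cc2)cc1` and compound 2 `O=C(c1ccccc1)N1CCC(NCC[S+]([O-])C(c2ccc(F)cc2)c2ccc(F)cc2)CC1` have both been tested in an assay on membranes from striatum (strain Sprague-Dawley) for displacement of a labelled ligand from sodium-dependent dopamine transporter (Rattus norvegicus), read by scintillation counting, with a stated time of 120 min; a lower number here means a stronger inhibitor, a higher number a weaker inhibitor. In this assay compound 1 gives 32.9 nM, while compound 2 gives 79.1 nM, the higher of the two numbers and a difference that lies beyond the usual scatter. Compound 3 `CC(C)(C)C(=O)N1CCC(NCC[S+]([O-])C(c2ccc(F)cc2)c2ccc(F)cc2)CC1` is not yet measured; it differs from compound 2 by tert-butyl in place of phenyl on a carbonyl carbon. Among the measured compounds shown here, with no measured step of this kind to lean on, a modest move toward a higher number is expected, a 1.9-fold higher number from compound 2 to compound 3 (0.28 log units; within the scatter), so that compound 3 is estimated at 150 nM, within a range from 50 nM to 500 nM.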

Compound 3, inhibition constant: 10200 nM
For compound 3 the middle estimate is 68-fold (1.83 log units) below the measured one; measured number above the stated range.
By their numbers in this assay, from the lowest: compound 1; then compound 2; then compound 3.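

Replacing phenyl with tert-butyl on a carbonyl carbon gives a 130-fold higher number from compound 2 to compound 3 (2.11 log units; beyond the scatter) in this assay, showing that this position tolerates this change poorly, a sensitivity that compounds 1 and 2, which differ in more than one place, could not reveal. The loss comes from a change in which neither group carries hydrogen-bond donors or acceptors, while the six-membered aromatic ring leaves. No available evidence accounts for its size. The compounds shown leave open whether cyclohexyl or pyridyl on this carbonyl carbon would stay closer to compound 2 or fall toward compound 3.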